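Acetylating the amine of compound 1

The source may hold more compounds than are shown below. What is called first, only, known or untested is meant among the compounds shown, and "the series" means these compounds.

In a functional assay on MDA-MB-468 cells (Homo sapiens) for antiproliferative activity (on this read-out lower numbers stand for stronger inhibition and higher numbers for weaker inhibition), compound 1 (`Cc1cc(-c2nc3ccccc3s2)ccc1N`) gives < 1 nM as a limit. Compound 2 (`Nc1ccc(-c2nc3ccccc3s2)cc1Br`) gives < 1 nM as a limit. Compound 3 (`Nc1ccc(-c2nc3ccccc3s2)cc1I`) gives < 1 nM as a limit. Going by the values given here, the series so far offers only the limit of < 1 nM in this assay, at which 3 of the 3 values shown sit, and no readable number.

Compound 4 (`CC(=O)Nc1ccc(-c2nc3ccccc3s2)cc1C`) turns amino to acetamido, with acetyl in place of hydrogen on a nitrogen on an aromatic ring. Among the compounds with values here, no measured step touches that nitrogen: a step that the two limits leave unreadable from compound 1 to compound 2 and a step that the two limits leave unreadable from compound 1 to compound 3 and a step that the two limits leave unreadable from compound 2 to compound 3 all exchange groups on an aromatic carbon and give no size.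

The estimated change is an at least 3.0-fold higher number from compound 1 to compound 4 (0.47 log units; beyond the scatter) toward weaker inhibition in this assay as a cautious expectation. Compound 4 is estimated at 3 nM (expected range 0.3 nM to 50 nM).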

Compound 4, half-maximal inhibitory concentration: > 10000 nM
Compound 4: no number, only a limit (the forecaster's own chance of this, stated with the estimate: 35%); at least 3300-fold (3.52 log units) between middle value and limit.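

Acetyl in place of hydrogen on a nitrogen on an aromatic ring gives an at least 10000-fold higher number from compound 1 to compound 4 (4.00 log units; beyond the scatter), toward weaker inhibition and the first step of readable size in this assay. The exchanges on an aromatic carbon among compound 1, compound 2 and compound 3 cannot be read, so this nitrogen is the only place where the series shows a response. The value of compound 4 is a limit, so the full size of the step stays unknown: the limit of > 10000 nM in this assay, at which 1 of the 4 values shown sits.

From the compounds shown here alone, whether a methyl group or a formyl group on that nitrogen would keep the activity of compound 1 remains open. So does the effect of a longer acyl chain there.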